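The compounds below may be only part of what the source reports. "The series", "measured", "known", "first", "only" and "open" are said of these compounds alone.

Compound 2 `COc1cc(/C=C/C(=O)C2=C(/C=C/c3ccc(O)c(OC)c3)NC(=S)NC2c2c(Cl)cccc2Cl)ccc1O` stands lowest of the two compounds measured in a functional assay, with a stated time of 20 min, tested at 20 uM; on this read-out higher numbers stand for a stronger effect at the one concentration tested and lower numbers for a weaker effect: compound 2 gives 43.2%, whereas compound 1 `COc1cc(/C=C/C(=O)C2=C(/C=C/c3ccc(O)c(OC)c3)NC(=S)NC2c2ccccc2O)ccc1O` gives 72.3%, and the step of a number 29.1 percentage points lower from compound 1 to compound 2 (beyond the scatter) is the only one seen so far. Compound 3 `COc1cc(/C=C/C(=O)C2=C(/C=C/c3ccc(O)c(OC)c3)NC(=S)NC2c2ccccc2Cl)ccc1O` differs from compound 2 by hydrogen in place of chloro on an aromatic carbon. Among the compounds with values here, no measured step matches this change; the one known step touches the same saturated ring carbon with a different group, so it bears on it only loosely. Compound 3 is expected to move part of the way back, with the step of a number 11.8 percentage points higher from compound 2 to compound 3 (beyond the scatter). Compound 3 is therefore estimated at 55%, in a range from 35% to 75%.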

Compound 3, a percentage reported as activity, at one concentration (the size of the read-out at that concentration, not a potency): 56.6%
Estimate against measurement, compound 3: 1.6 percentage points below; low and high end bracket the measured number.
By their numbers in this assay, from the lowest: compound 2; then compound 3; then compound 1.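

Taking one chloro off the 2,6-dichlorophenyl group to leave 2-chlorophenyl gives a number 13.4 percentage points higher from compound 2 to compound 3 (beyond the scatter) in this assay, so this aromatic carbon responds to a single-atom change. The remaining chloro also matters when set against hydroxy on the aromatic carbon: that exchange gives a number 15.7 percentage points lower from compound 1 to compound 3 (beyond the scatter) on the same read-out. Nothing measured on these compounds explains either step.

From the compounds shown here alone, the plain phenyl group, with neither chloro nor hydroxy, remains open. So does an amine or a carboxylic acid on this aromatic carbon.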